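The source may hold more compounds than are shown below. What is called first, only, known or untested is meant among the compounds shown, and "the series" means these compounds.

Measured in an ADME assay on THP-1 cells (Homo sapiens) for cytotoxicity, read by flow cytometry and propidium iodide staining, with a stated time of 72 h; a lower number here means a stronger inhibitor, a higher number a weaker inhibitor:

Compound 1 `COc1cccc(/C=C/C(=O)c2cc(NC(C)=O)ccc2O)c1` gives 93700 nM.
Compound 2 `CC(=O)Nc1ccc(O)c(C(=O)/C=C/c2cccc(F)c2)c1` gives 78600 nM.
Compound 3 `COc1ccccc1-c1oc2ccc(N)cc2c(=O)c1O` gives 102000 nM.

Compound 1 and compound 2 share one core and differ only by fluoro in place of methoxy on an aromatic carbon. That change made a 1.2-fold lower number from compound 1 to compound 2 (0.08 log units; within the scatter). Compound 3 has a different core; how its core differs from the core of compound 1 is not broken down here. Its value and those of compound 1 and compound 2 lie within the usual scatter of one another, so none of the three stands apart.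

Compound 4 `Nc1ccc2oc(-c3ccccc3F)c(O)c(=O)c2c1` has not been measured. It comes from compound 3 by fluoro in place of methoxy on an aromatic carbon. Among the measured compounds shown here, this is the same kind of change as the one from compound 1 to compound 2, but the place is not the same: there the fluoro sits meta to a large group, here it sits ortho to a large group. For the measured compounds named here, with only the one earlier step to go on, and that step within the scatter, a step of similar size is expected, namely a 1.2-fold lower number from compound 3 to compound 4 (0.06 log units; within the scatter), resting on a 1.2-fold lower number from compound 1 to compound 2 (0.08 log units; within the scatter). Compound 4 is therefore estimated at 88000 nM, between 45000 nM and 170000 nM.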

Compound 4, half-maximal inhibitory concentration: 38000 nM
Compound 4: the middle estimate sits 2.3-fold (0.36 log units) above what was measured; measured number outside the range, below it.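

In this assay, fluoro in place of methoxy gave a 2.7-fold lower number from compound 3 to compound 4 (0.43 log units; beyond the scatter), a step beyond the scatter, while the same change on the other core gave a 1.2-fold lower number from compound 1 to compound 2 (0.08 log units; within the scatter). Set side by side, the two steps do not differ by more than repeated measurement alone could produce: the same change on two cores in this assay, a 1.2-fold lower number (0.08 log units; within the scatter) from compound 1 to compound 2 and a 2.7-fold lower number (0.43 log units; beyond the scatter) from compound 3 to compound 4, 2.3-fold (0.35 log units) apart, within the scatter of two such steps. So there is no firm sign that the core alters the result of this change, but neither is it shown that the two cores respond alike: there is only one pair per core, the first step lies within the scatter, and the fluoro does not sit in the same place on the two cores.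

The compounds shown leave open whether another group in place of methoxy on that aromatic carbon, such as chloro, methyl or an amine, would give similar steps on both cores. They also leave open what the fluoro step would be at other places on the same ring of each core.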